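Replacing thiophen-3-yl with 2-chlorophenyl in a weak series

A few compounds are considered here, and "the series" means these few. Any claim that something is new, unique, unknown or untested is made for them only; others in the source may bear on it.

For the measured compounds named here, in a functional assay on K562 cells (Homo sapiens) for antiproliferative activity, with a stated time of 72 h (a higher number here means a weaker inhibitor, a lower number a stronger inhibitor), compound 2 `Nc1ncnn2c([C@@H]3O[C@H](CO)[C@@H](O)[C@H]3O)cc(-c3ccsc3)c12` gives 66400 nM, the only true number so far. Compound 1 `Cc1ccccc1-c1cc([C@@H]2O[C@H](CO)[C@@H](O)[C@H]2O)n2ncnc(N)c12` gives > 100000 nM, which is a limit of the assay and not a number. Compound 3 `Nc1ncnn2c([C@@H]3O[C@H](CO)[C@@H](O)[C@H]3O)cc(-c3ccccc3Cl)c12` keeps the core of compound 2 and changes one group: 2-chlorophenyl in place of thiophen-3-yl on an aromatic carbon. Going by the values given here, one measured step bears on this change, an at least 1.5-fold lower number from compound 1 to compound 2 (0.17 log units; that floor lies within the scatter), and the floor of that step lies within the scatter. Compound 1 carries 2-methylphenyl, the group closest to the incoming 2-chlorophenyl, so compound 3 may behave much like compound 1. A small move towards a higher number in this assay is therefore expected, though one that may stay within the scatter. The expected change is a 1.2-fold higher number from compound 2 to compound 3 (0.08 log units; within the scatter). For compound 3 the estimated value is 80000 nM, with an expected range from 35000 nM to 100000 nM.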

Compound 3, half-maximal inhibitory concentration: > 100000 nM
Compound 3 ended at the assay's limit (the forecaster's own chance of this, stated with the estimate: 50%); at least 1.2-fold (0.09 log units) between middle value and limit.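

In this assay, putting 2-chlorophenyl in place of thiophen-3-yl on this aromatic carbon gives an at least 1.5-fold higher number from compound 2 to compound 3 (0.17 log units; that floor lies within the scatter), and because compound 3 has only a limit of the assay and not a number, the true step could be larger. Compound 3 now shares that limit with compound 1, so both compounds with an ortho-free description aside fall into one group: the limit of > 100000 nM in this assay, at which 2 of the 3 values shown sit. The step between compound 1 and compound 3, chloro in place of methyl, cannot be read, as both values are limits.

The compounds shown leave open whether a plain phenyl ring, an amine or a carboxylic acid on this aromatic carbon would move the number clearly away from that of compound 2 at 66400 nM. They also leave open whether any group here can turn this weak series into a strong one.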